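From Benzoyl to Phenoxymethyl on a Shared Core

This account rests on a few compounds, and the source may have more. Where it says the series, first, only, none or still open, it means among the compounds named here.

Compound 1 `CCS(=O)(=O)N(Cc1cccnc1)c1cccc(C(=O)c2ccccc2)c1` and compound 2 `CCS(=O)(=O)N(Cc1cccnc1)c1ccc(C(C)c2ccccc2)cc1` share a common core and were both tested in an assay on isolated protein with metabotropic glutamate receptor 2 (Homo sapiens) as the target; on this read-out higher numbers stand for an effect only at larger amounts of compound and lower numbers for an effect already at smaller amounts. In this assay compound 1 gives 1100 nM, and compound 2 gives 1400 nM. Among the numbers shown, compound 1 stands at one end, with compound 2 a short distance away, a gap that lies within the usual scatter of such measurements, so the two cannot be told apart on this basis.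

Compound 3 `CCS(=O)(=O)N(Cc1cccnc1)c1cccc(COc2ccccc2)c1` has not yet been measured. It differs from compound 1 in a single place: phenoxymethyl in place of benzoyl on an aromatic carbon. Within the data shown here, no measured pair in this set shows what such a swap does, so there is nothing to lean on beyond the observation that two compounds carrying attachments of similar size, compound 1 and compound 2, land close together in this assay. The expected step is therefore a 1.4-fold higher number from compound 1 to compound 3 (0.13 log units; within the scatter), a small one with no clear direction beyond the scatter. Compound 3 is estimated to give 1500 nM in this assay, within a range from 500 nM to 4500 nM.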

Compound 3, half-maximal effective concentration: 160 nM
Estimate against measurement, compound 3: 9.4-fold (0.97 log units) above; the whole stated range lies above it.
By their numbers in this assay, from the lowest: compound 3; then compounds 1 and 2 (each within the scatter of the next).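

In this assay, the swap on this aromatic carbon, meta to a large group, gives a 6.9-fold lower number from compound 1 to compound 3 (0.84 log units; beyond the scatter) and shows that this position responds clearly to the identity of the attached group. The result is striking given how much the two groups have in common: benzoyl and phenoxymethyl match in heavy atoms, in their carbon and oxygen counts, in their aromatic ring and in their hydrogen-bond donors and acceptors, and the one counted difference is the double bond outside aromatic rings that leaves with benzoyl, so matching counts alone do not guarantee a matching number here. No measured property of these groups is available to explain the step, and its origin remains unknown.

As far as these compounds go, it remains open whether the step depends on the oxygen in the phenoxymethyl link or on the loss of the carbonyl, a question that phenethyl, with carbon in place of that oxygen, or anilinomethyl, with an amine nitrogen there, could help to settle. Also open, from the compounds shown here alone, is whether the lower number survives a fluorine or a methoxy group on the phenoxymethyl ring.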